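Shortening the side chain: from compound 1 to compound 4

This account rests on a few compounds, and the source may have more. Where it says the series, first, only, none or still open, it means among the compounds named here.

Measured compounds:
- compound 1, `COC(=O)[C@@H](CC(C)C)NC(=O)Cn1cc(C2=C(c3c[nH]c4ccccc34)C(=O)N(C)C2=O)c2ccccc21`: 37800 nM
- compound 2, `COC(=O)[C@@H](C)NC(=O)Cn1cc(C2=C(c3c[nH]c4ccccc34)C(=O)N(C)C2=O)c2ccccc21`: 21400 nM
- compound 3, `COC(=O)[C@H](NC(=O)Cn1cc(C2=C(c3c[nH]c4ccccc34)C(=O)N(C)C2=O)c2ccccc21)[C@@H](C)O`: 23400 nM

All three were tested in a functional assay on HCT-8 cells (Homo sapiens) for cytotoxicity, read by MTT assay, with a stated time of 24 h; on this read-out higher numbers stand for weaker inhibition and lower numbers for stronger inhibition. On these numbers compound 1 has the highest value, but neither neighbour is far from it: the step of a 1.8-fold lower number from compound 1 to compound 2 (0.25 log units; within the scatter) and the step of a 1.6-fold lower number from compound 1 to compound 3 (0.21 log units; within the scatter) both stay within the scatter, and the step of a 1.1-fold higher number from compound 2 to compound 3 (0.04 log units; within the scatter) is smaller still. The three compounds therefore share the same core and behave alike in this assay, whatever group sits on the saturated chain carbon bound to the amide-type nitrogen and the carbonyl carbon.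

Compound 4, `COC(=O)[C@H](NC(=O)Cn1cc(C2=C(c3c[nH]c4ccccc34)C(=O)N(C)C2=O)c2ccccc21)C(C)C`, is not yet measured. It differs from compound 1 in one place: isopropyl in place of isobutyl on a saturated chain carbon bound to an amide-type nitrogen and a carbonyl carbon. The two steps that bear on it, from compound 1 to compound 2 and from compound 1 to compound 3, each changed the same group and each gave only a slightly lower number within the scatter. A similar outcome is expected here, a step of a 1.4-fold lower number from compound 1 to compound 4 (0.13 log units; within the scatter) that does not rise beyond the scatter. Compound 4 is therefore estimated at 28000 nM in this assay, with a range from 14000 nM to 56000 nM.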

Compound 4, half-maximal inhibitory concentration: 25800 nM
The estimate for compound 4 lay 1.1-fold (0.04 log units) above the measured number, and the stated range covers the measured number.
By their numbers in this assay, from the lowest: compounds 2, 3, 4 and 1 (each within the scatter of the next).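

Isopropyl on the saturated chain carbon bound to an amide-type nitrogen and a carbonyl carbon gives a carbon-only group branched at its first carbon, and in this assay it stays close to the other three groups: the steps are a 1.5-fold lower number from compound 1 to compound 4 (0.17 log units; within the scatter) and a 1.1-fold higher number from compound 3 to compound 4 (0.04 log units; within the scatter) and also a 1.2-fold higher number from compound 2 to compound 4 (0.08 log units; within the scatter) and all of them lie within the scatter. Methyl, isopropyl, 1-hydroxyethyl and isobutyl therefore cannot be told apart at this position in compounds 1 to 4, so the swap from isobutyl to isopropyl adds a fourth group with no readable effect. Nothing available explains this flat result.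

Still open, as far as these compounds go, is whether a different kind of group on this carbon, such as an amine, a carboxylic acid or a phenyl ring, would move the number beyond the scatter. Also open, from the compounds shown here alone, is whether a longer chain would do so.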